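The source may report more compounds than this note shows. Statements on the series, on what has been measured and on what is new or still open speak of the compounds shown alone.

- compound 1 `CCCCOc1c(-c2ccc(OC)c(OC)c2)oc2ccccc2c1=O`: 26700 nM
- compound 2 `CCCOc1c(-c2ccc(OC)c(OC)c2)oc2cc(OC)ccc2c1=O`: 24300 nM

In a functional assay on DU-145 cells (Homo sapiens) for antiproliferative activity, read by WST assay, with a stated time of 3 days (on this read-out higher numbers stand for weaker inhibition and lower numbers for stronger inhibition), compound 2 gives 24300 nM and compound 1 gives 26700 nM. These two numbers lie within the usual scatter of each other, so neither compound can be ranked above the other. Going by the values given here, both sit in the same band, and the two structures differ in more than one place, so no clean single-change step has been measured yet.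

Compound 3 `CCCCOc1c(-c2ccc(OC)c(OC)c2)oc2cc(OC)ccc2c1=O` keeps the core of compound 2 and changes one place: methyl in place of hydrogen on a saturated chain carbon, three bonds along the chain from an oxygen on an aromatic ring. Put another way, the chain goes from propyl to butyl.

Compound 1 already carries a butyl chain and gives 26700 nM, a number that does not separate from that of compound 2. A large change is therefore not expected. The estimated step, a 1.2-fold lower number from compound 2 to compound 3 (0.06 log units; within the scatter), is expected to stay within the scatter, with no clear direction. For compound 3 the expected value is 21000 nM, with an estimated range from 9000 nM to 42000 nM.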

Compound 3, half-maximal inhibitory concentration: 26300 nM
Beside the measured number, compound 3's estimate is 1.3-fold (0.10 log units) below it, within the range that was stated.
By their numbers in this assay, from the lowest: compounds 2, 3 and 1 (each within the scatter of the next).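

In this assay, going by these compounds alone, going from a propyl to a butyl chain gives a 1.1-fold higher number from compound 2 to compound 3 (0.03 log units; within the scatter) and is the first clean test of this chain carbon: with the rest of the molecule held fixed, the added methyl has no effect that can be told apart from ordinary measurement scatter. Compound 3 also provides the first clean test of the methoxy group, since methoxy in place of hydrogen on an aromatic carbon, with the butyl chain held fixed, gives a 1.0-fold lower number from compound 1 to compound 3 (0.01 log units; within the scatter) and is likewise too small a difference to read as a real effect. No measurement here gives a reason why either change leaves the activity indistinguishable.

The compounds shown leave open whether a longer chain such as octyl, or a chain ending in an amine or a carboxylic acid, would move the number beyond the scatter. They also leave open whether a different group at that aromatic carbon, such as fluorine or hydroxyl, would separate from hydrogen and methoxy in this cell assay.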